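This account rests on a few compounds, and the source may have more. Where it says the series, first, only, none or still open, it means among the compounds named here.

Measured so far:
Compound 1, `O=C(NCc1cc(Cl)ccc1-n1cnnn1)[C@@H]1C[C@@H]2C[C@@H]2N1C(=O)[C@H](O)CC1CC1`: in an ADME assay on liver for metabolic stability, with Liver microsome (Homo sapiens) as the target, read by LC-MS, using microsomes (a lower number here means slower removal, a higher number faster removal of the compound), compound 1 gives < 12 mL.min-1.g-1, which is a limit of the assay rather than a number.
Compound 2, `CC(C)(C)OC[C@@H](O)C(=O)N1[C@H](C(=O)NCc2cc(Cl)ccc2-n2cnnn2)C[C@@H]2C[C@@H]21`: in this assay compound 2 gives 21 mL.min-1.g-1.
Compound 3, `CC(C)(C)OC[C@@H](O)C(=O)N1C[C@@H]2C[C@@H]2[C@H]1C(=O)NCc1cc(Cl)ccc1-n1cnnn1`: in this assay compound 3 gives 37 mL.min-1.g-1.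

Compound 2 and compound 3 are built from the same atoms joined differently; the difference between their two cores is not broken down here, and their two values lie within the usual scatter of each other. Compound 1 arises from compound 2 by cyclopropyl in place of tert-butoxy on a saturated chain carbon, two bonds along the chain from a carbonyl carbon and an oxygen on a saturated carbon. That change gave an at least 1.7-fold lower number from compound 2 to compound 1 (0.24 log units; that floor lies within the scatter), with compound 1 sitting at the limit of < 12 mL.min-1.g-1 in this assay, at which 1 of the 3 values shown sits.

Compound 4, `O=C(NCc1cc(Cl)ccc1-n1cnnn1)[C@@H]1[C@H]2C[C@H]2CN1C(=O)[C@H](O)CC1CC1`, which has not been measured, arises from compound 3 by the same change, (cyclopropyl in place of tert-butoxy on a saturated chain carbon, two bonds along the chain from a carbonyl carbon and an oxygen on a saturated carbon), at the same place. In this assay compound 4 is therefore expected to show a 2.1-fold lower number from compound 3 to compound 4 (0.31 log units; beyond the scatter), an estimate resting on compound 1 and compound 2 and their step of an at least 1.7-fold lower number from compound 2 to compound 1 (0.24 log units; that floor lies within the scatter). The estimate for compound 4 is 18 mL.min-1.g-1, expected to fall between 9 mL.min-1.g-1 and 32 mL.min-1.g-1.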

Compound 4, intrinsic clearance in microsomes: < 14 mL.min-1.g-1
Compound 4: only a limit was reported (the forecaster's own chance of this, stated with the estimate: 25%); middle value at least 1.2-fold (0.10 log units) from the limit.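

Carried from one core to the other, the swap of tert-butoxy for cyclopropyl again points to slower removal in this assay, with an at least 2.6-fold lower number from compound 3 to compound 4 (0.42 log units; beyond the scatter). Compound 4 gives < 14 mL.min-1.g-1, which is a limit of the assay and not a number, so this step gives only the smallest size the change can have on this core, and its true size may be larger. The lower number therefore carries over to a second core in direction, but the data cannot show whether the change is equally large on both cores, and the step on the first core is only a floor that lies within the usual scatter: the same change on two cores in this assay, an at least 1.7-fold lower number (0.24 log units; that floor lies within the scatter) from compound 2 to compound 1 and an at least 2.6-fold lower number (0.42 log units; beyond the scatter) from compound 3 to compound 4; the limit leaves it open whether they differ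

Going by these compounds, whether an amine, a carboxylic acid or a longer chain at the same place would also give a lower number remains open. Also open, on these data alone, is whether the swap from tert-butoxy to cyclopropyl would behave the same way on any core beyond these two.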